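N-aryl piperazine sulfonamides on a xanthine core

This account rests on a few compounds, and the source may have more. Where it says the series, first, only, none or still open, it means among the compounds named here.

Measured so far in an assay on CHO cells for displacement of a labelled ligand from adenosine receptor A2b (Homo sapiens), read by scintillation counting, with a stated time of 75 min, in the presence of a further agent that is not named here; a higher number here means a weaker inhibitor, a lower number a stronger inhibitor:
compound 1 `CCCn1c(=O)[nH]c2nc(-c3ccc(S(=O)(=O)N4CCN(C)CC4)cc3)[nH]c2c1=O`: 48.2 nM
compound 2 `CCCn1c(=O)[nH]c2nc(-c3ccc(S(=O)(=O)N4CCN(c5cccc(F)c5)CC4)cc3)[nH]c2c1=O`: 0.632 nM

Compound 1 carries a methyl on the amine nitrogen of the piperazine ring and gives the highest number of the two measured compounds; its nearest neighbour is compound 2, reached by a 76-fold lower number from compound 1 to compound 2 (1.88 log units; beyond the scatter). Among the measured compounds shown here, that step, 3-fluorophenyl in place of methyl on an amine nitrogen in a ring, is the only measured change in the set and is large.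

Compound 3 `CCCn1c(=O)[nH]c2nc(-c3ccc(S(=O)(=O)N4CCN(c5ccccc5)CC4)cc3)[nH]c2c1=O` is not yet measured. It differs from compound 1 as follows: phenyl in place of methyl on an amine nitrogen in a ring

For the measured compounds named here, the one step that bears on this change is the step from compound 1 to compound 2, where a closely related aryl group entered at the same nitrogen and the number fell far beyond the scatter. A phenyl without the fluorine is expected to behave in the same direction, with the size of the step taken as similar or somewhat smaller. On that basis the expected step is a 32-fold lower number from compound 1 to compound 3 (1.51 log units; beyond the scatter), and compound 3 is estimated at 1.5 nM in this assay, with a range from 0.4 nM to 6 nM.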

Compound 3, inhibition constant: 0.643 nM
Compound 3: the middle estimate sits 2.3-fold (0.37 log units) above what was measured; measured number inside the range.
By their numbers in this assay, from the lowest: compounds 2 and 3 (each within the scatter of the next); then compound 1.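

In this assay, the unsubstituted phenyl on the amine nitrogen in the ring is enough for a large step on its own: a 75-fold lower number from compound 1 to compound 3 (1.87 log units; beyond the scatter). The fluoro of compound 2 therefore makes no readable contribution at the aromatic carbon it occupies, since hydrogen in its place gives a 1.0-fold higher number from compound 2 to compound 3 (0.01 log units; within the scatter), and compound 2 and compound 3 cannot be ordered in this assay. What the series now shows at this nitrogen is that both aryl groups tested, phenyl and 3-fluorophenyl, stand apart from methyl, although no supporting measurement is available to explain this.

As far as these compounds go, it remains open whether the aromatic ring itself is needed, which a cyclohexyl or a benzyl group on the same nitrogen would help to settle. From the compounds shown here alone, it is also open whether the phenyl ring tolerates other substituents as it does the fluoro, for example a methoxy group, a chlorine, a nitrile or a carboxylic acid.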